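The source may report more compounds than this note shows. Statements on the series, on what has been measured and on what is new or still open speak of the compounds shown alone.

Measured so far in this series:
Compound 1, `C[C@H](NC(=O)c1c(-c2ccccc2)nnn1Cc1ccc(F)cc1)c1ccc(C(=O)O)cc1`: 330 nM
Compound 2, `C[C@H](NC(=O)c1c(-c2ccccc2)nnn1Cc1cccc(C(F)(F)F)c1)c1ccc(C(=O)O)cc1`: 23 nM
Compound 3, `COc1ccc(Cn2nnc(-c3ccccc3)c2C(=O)N[C@@H](C)c2ccc(C(=O)O)cc2)cc1OC`: 119 nM

All three were tested in a functional assay on CHO cells for antagonist activity at prostaglandin E2 receptor EP4 subtype (Homo sapiens), read by calcium flux, with a stated time of 15 min; a lower number here means a stronger inhibitor, a higher number a weaker inhibitor. Compound 3 has the second highest number of the three and so sits in the middle. Compared with compound 1 the step is a 2.8-fold lower number from compound 1 to compound 3 (0.44 log units; beyond the scatter); compared with compound 2, the strongest of the three, the step is a 5.2-fold higher number from compound 2 to compound 3 (0.71 log units; beyond the scatter). Both steps are beyond the scatter.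

Compound 4, `C[C@H](NC(=O)c1c(-c2ccccc2)nnn1CCOc1ccc(F)cc1)c1ccc(C(=O)O)cc1`, has not yet been measured. It differs from compound 3 in one place: (4-fluorophenoxy)methyl in place of 3,4-dimethoxyphenyl on a saturated chain carbon bound to an aromatic nitrogen. The group that enters carries the same fluorinated ring found in compound 1, but set one bond further from the shared core through an oxygen. The measured steps show that changing this ring matters: a 14-fold lower number from compound 1 to compound 2 (1.16 log units; beyond the scatter) and a 2.8-fold lower number from compound 1 to compound 3 (0.44 log units; beyond the scatter). For the measured compounds named here, no measured step tells what lengthening the link does, so the comparison with compound 1 is the closest guide, and compound 1 is weaker than compound 3. Compound 4 is therefore expected to give about 250 nM, within 80 nM to 800 nM. The expected step from compound 3 is a 2.1-fold higher number from compound 3 to compound 4 (0.32 log units; beyond the scatter), a modest loss with wide uncertainty.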

Compound 4, half-maximal inhibitory concentration: 3.1 nM
Compound 4: middle estimate off by 81-fold (1.91 log units), on the high side, outside the stated range (below it).
By their numbers in this assay, from the lowest: compound 4; then compound 2; then compound 3; then compound 1.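

Within this assay, the group on the saturated chain carbon bound to an aromatic nitrogen turns out to depend on more than what decorates the ring. Compound 1 and compound 4 carry the same fluorinated ring, yet reaching it through the longer, oxygen-containing link of (4-fluorophenoxy)methyl gives a 110-fold lower number from compound 1 to compound 4 (2.03 log units; beyond the scatter) and so changes far more than the fluorine alone could show. The same group also gives a 38-fold lower number from compound 3 to compound 4 (1.58 log units; beyond the scatter) and a 7.4-fold lower number from compound 2 to compound 4 (0.87 log units; beyond the scatter) and makes compound 4 the strongest of the four, so the link can outweigh the ring changes seen in compound 2 and compound 3.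

Nothing measured in this set gives a reason for this gain. On these data alone, the link in compound 4 differs from that in compound 1 in both length and the presence of oxygen, so it remains open which of these matters, a question that 3-(4-fluorophenyl)propyl, with an all-carbon link, could help answer, while 2-(3-(trifluoromethyl)phenoxy)ethyl could show whether the ring change from compound 2 adds to the gain from the longer link.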